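A Dimethylamino Group Replacing the Pyridinyl Ring

The source may report more compounds than this note shows. Statements on the series, on what has been measured and on what is new or still open speak of the compounds shown alone.

Among the compounds with values here, compound 2 `O=C(CSc1nc2c(c(=O)n1-c1ccccc1)SCC2)Nc1ccc(-c2ccncc2)cc1` carries a pyridin-4-yl group and gives 3 nM in an assay on L cells for inhibition of Protein-serine O-palmitoleoyltransferase porcupine (Mus musculus), read by reporter gene assay, with a stated time of 24 h (a lower number here means that less compound is needed, a higher number that more compound is needed for the effect), the lowest of the two numbers measured so far. Within the data shown here, its nearest neighbour is compound 1 `CCOc1ccc(NC(=O)CSc2nc3c(c(=O)n2-c2ccccc2)SCC3)cc1`, which carries an ethoxy group in the same place and gives 1000 nM in this assay; the step of a 330-fold lower number from compound 1 to compound 2 (2.52 log units; beyond the scatter) is the only measured step, and it is large. Compound 3 `CN(C)c1ccc(NC(=O)CSc2nc3c(c(=O)n2-c2ccccc2)SCC3)cc1` has not yet been measured. It differs from compound 2 by a single change: dimethylamino in place of pyridin-4-yl on an aromatic carbon. Among the measured compounds shown here, the only measured step that bears on this change is a 330-fold lower number from compound 1 to compound 2 (2.52 log units; beyond the scatter), in which a small group without a ring gave way to the aromatic ring and the number fell sharply; the change now runs the other way, from that ring back to a small group with no ring, and therefore points to a much higher number in this assay. The dimethylamino group, like the ethoxy group of compound 1, contains no ring, so compound 3 is expected to land near compound 1 rather than near compound 2. Compound 3 is estimated at 1000 nM, within 200 nM to 5000 nM. This estimate means an expected step of a 330-fold higher number from compound 2 to compound 3 (2.52 log units; beyond the scatter).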

Compound 3, half-maximal effective concentration: > 1000 nM
Compound 3: no number, only a limit; the forecaster's own chance of this, stated with the estimate: 10%; the middle value lies on the limit itself.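

Compound 3 gives no number in this assay, only a limit: the limit of > 1000 nM in this assay, at which 1 of the 3 values shown sits. With dimethylamino in place of pyridin-4-yl on an aromatic carbon, the piece records an at least 330-fold higher number from compound 2 to compound 3 (2.52 log units; beyond the scatter), so the low number of compound 2 is now lost with a second group that has no ring, and not with ethoxy alone. With dimethylamino in place of ethoxy on an aromatic carbon, the piece records a number no lower from compound 1 to compound 3 (the limit leaves the size open); the size of this step cannot be read, so dimethylamino and ethoxy cannot be placed in order at this position.

The compounds shown do not separate the presence of an aromatic ring from the presence of the nitrogen within it, as neither phenyl, whose ring holds carbon only, nor pyridin-3-yl, with the nitrogen elsewhere in the ring, is among them. They also leave open how a ring without aromatic character, such as morpholine or piperidine, would fare in this place, and whether any group with no ring, such as a longer chain or a carboxylic acid, could come near the number of compound 2.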